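A few compounds are considered here, and "the series" means these few. Any claim that something is new, unique, unknown or untested is made for them only; others in the source may bear on it.

Compound 1 `Cc1cc(/C=C/c2ccc(O)cc2)[nH]n1` gives 48100 nM
Compound 2 `COc1ccc(/C=C/c2cc(C)n[nH]2)cc1` gives 8900 nM
Compound 3 `COc1ccc(/C=C/c2cc(C)no2)cc1OC` gives > 100000 nM

For the measured compounds named here, in a functional assay on PC-3 cells (Homo sapiens) for cytotoxicity, read by MTT assay, with a stated time of 72 h (a lower number here means a stronger inhibitor, a higher number a weaker inhibitor), compound 1 at 48100 nM is the higher of the two true numbers so far. Compound 3 gives > 100000 nM as a limit of the assay, not a number. Compound 4 `Cc1cc(/C=C/c2ccc(O)c(O)c2)[nH]n1` keeps the core of compound 1 but carries hydroxy in place of hydrogen on an aromatic carbon. Going by the values given here, the one measured step between close neighbours is a 5.4-fold lower number from compound 1 to compound 2 (0.73 log units; beyond the scatter) and it alters the existing hydroxy group rather than adding a new one. Taking that modest step as a rough guide to size, a step no larger is expected in this assay, probably toward a lower number, though the direction is uncertain. The expected step is a 1.7-fold lower number from compound 1 to compound 4 (0.23 log units; within the scatter) here. For compound 4 the estimated value is 28000 nM, with an expected range of 9000 nM to 90000 nM.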

Compound 4, half-maximal inhibitory concentration: 23200 nM
The estimate for compound 4 lay 1.2-fold (0.08 log units) above the measured number; measured number inside the range.
By their numbers in this assay, from the lowest: compound 2; then compound 4; then compound 1. At a limit, above all of these: compound 3.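

In this assay there is a 2.1-fold lower number from compound 1 to compound 4 (0.32 log units; beyond the scatter) on placing hydroxy on an aromatic carbon ortho to a hydroxy group, so a newly added group, and not only a change to the existing hydroxy, can move the number. This carbon therefore takes a new hydroxy with a modest fall in the number rather than a rise. Nothing measured here accounts for this shift.

It remains open whether the shift is particular to hydroxy, since no amine, fluorine or carboxylic acid on this same carbon appears among these compounds.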